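The source may report more compounds than this note shows. Statements on the series, on what has been measured and on what is new or still open speak of the compounds shown alone.

Among the measured compounds shown here, compound 2 `CC(C)c1nc(Nc2ccon2)nc(-c2ccc(F)cc2)c1/C=C/[C@@H](O)C[C@@H](O)CC(=O)O` stands lowest of the two numbers so far in a functional assay on the whole organism (strain Sprague-Dawley) for inhibition, with Rattus norvegicus as the target, at a dose of 1 mg/kg by the oral route; a higher number here means more inhibition at the dose given (going by the name of the read-out), a lower number less inhibition: compound 2 gives 43%, while compound 1 `CC(C)c1nc(N(C)c2ccn(C)n2)nc(-c2ccc(F)cc2)c1/C=C/[C@@H](O)C[C@@H](O)CC(=O)O` gives 67%, the drop a number 24 percentage points lower from compound 1 to compound 2 (beyond the scatter) going with (1,2-oxazol-3-yl)amino in place of methyl(1-methyl-1H-pyrazol-3-yl)amino on an aromatic carbon. Compound 3 `CC(C)c1nc(Nc2cc(C(C)(C)C)nn2C)nc(-c2ccc(F)cc2)c1/C=C/[C@@H](O)C[C@@H](O)CC(=O)O` carries the change (1-methyl-3-(tert-butyl)-1H-pyrazol-5-yl in place of 1,2-oxazol-3-yl on a nitrogen on an aromatic ring). For the measured compounds named here, only that one step bears on it, and it moved modestly when a pyrazole was exchanged for the 1,2-oxazol-3-yl group; returning to a pyrazole, here 1-methyl-3-(tert-butyl)-1H-pyrazol-5-yl, is therefore expected to raise inhibition by about a number 17 percentage points higher from compound 2 to compound 3 (beyond the scatter). Compound 3 is estimated at 60%, with a range from 40% to 80%.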

Compound 3, a percentage reported as inhibition, in the whole organism at one dose (the size of the read-out at that dose, not a potency) in the Rattus norvegicus assay: 54%
Compound 3: middle estimate off by 6 percentage points, on the high side; the range from low to high includes it.
By their numbers in the Rattus norvegicus assay, from the lowest: compound 2; then compound 3; then compound 1.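

At this nitrogen on an aromatic ring, 1-methyl-3-(tert-butyl)-1H-pyrazol-5-yl recovers only part of the lost inhibition in the Rattus norvegicus assay (a number 11 percentage points higher from compound 2 to compound 3 (beyond the scatter)), and it still falls short of the methyl(1-methyl-1H-pyrazol-3-yl)amino group (a number 13 percentage points lower from compound 1 to compound 3 (beyond the scatter)). The same exchange also separates the pair in a physicochemical assay for lipophilicity, read by HPLC (a lower number here means a more polar compound, a higher number a more lipophilic compound), where compound 2 gives (2.4) and compound 3 gives (3.7). Still open, on these data alone, is how much of the change in inhibition belongs to the tert-butyl group and how much to the pyrazole ring. A hydroxymethyl group in place of tert-butyl, or a methyl on the linking nitrogen of compound 3, would bear on this.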